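A few compounds are considered here, and "the series" means these few. Any claim that something is new, unique, unknown or untested is made for them only; others in the source may bear on it.

Measured compounds:
compound 1 `NC(=O)CC[C@H](NC(=O)CN(c1ncnc2c1ncn2C1CCCCO1)C1CC1)C(=O)OCc1ccccc1`
compound 2 `O=C(CN(c1ncnc2c1ncn2C1CCCCO1)C1CC1)NCC(=O)OCc1ccccc1`
compound 3 `NC(=O)C[C@H](NC(=O)CN(c1ncnc2c1ncn2C1CCCCO1)C1CC1)C(=O)OCc1ccccc1`

In a functional assay on the whole organism (Tail, strain ICR) with Mus musculus as the target, in the tail flick test, with a stated time of 90 min, at a dose of 25 umol/kg by the oral route (on this read-out higher numbers stand for a stronger effect at the one dose given and lower numbers for a weaker effect), compound 1 gives 37.8%, compound 2 gives 25.9% and compound 3 gives 35%. On the raw numbers compound 3 sits between the other two, yet a number 2.8 percentage points lower from compound 1 to compound 3 (within the scatter) and a number 9.1 percentage points higher from compound 2 to compound 3 (within the scatter) both fall within scatter. Compound 4 `CC(C)(C)OC(=O)NCCCC[C@H](NC(=O)CN(c1ncnc2c1ncn2C1CCCCO1)C1CC1)C(=O)OCc1ccccc1` carries the change (3-((tert-butoxycarbonyl)amino)propyl in place of carbamoyl on a saturated chain carbon, two bonds along the chain from an amide-type nitrogen and a carbonyl carbon). The steps touching this position show that only removal of the side chain, a number 11.9 percentage points lower from compound 1 to compound 2 (beyond the scatter), moved the read-out beyond scatter, whereas exchanging one chain for another did not. A longer chain is therefore expected to give no step beyond scatter, a number 2 percentage points lower from compound 3 to compound 4 (within the scatter). Compound 4 is estimated at 33%, between 18% and 48%.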

Compound 4, a percentage reported as activity, at one dose (the size of the read-out at that dose, not a potency): 32.9%
Estimate against measurement, compound 4: 0.1 percentage points above; measured number inside the range.
By their numbers in this assay, from the lowest: compounds 2, 4, 3 and 1 (each within the scatter of the next, the first and the last beyond it).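

In this assay, the 3-((tert-butoxycarbonyl)amino)propyl chain is accepted at this position in place of carbamoyl, with a number 2.1 percentage points lower from compound 3 to compound 4 (within the scatter) and a number 4.9 percentage points lower from compound 1 to compound 4 (within the scatter). The carbamoyl group is therefore not needed for a value within scatter of compound 1 and compound 3 . However, with a number 7 percentage points higher from compound 2 to compound 4 (within the scatter), this chain is also not separated from the hydrogen of compound 2, so the series cannot show that the new chain adds to the read-out.

Nothing measured here bears on why the chain change leaves the read-out level. Going by these compounds, whether a free amine or a carboxylic acid in place of the ((tert-butoxycarbonyl)amino) group would behave the same remains open.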